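The source may hold more compounds than are shown below. What is called first, only, known or untested is meant among the compounds shown, and "the series" means these compounds.

Working notes on the series, read in a functional assay on Huh-7 cells (Homo sapiens) for cytotoxicity, read by MTT assay, with a stated time of 72 h; on this read-out higher numbers stand for lower toxicity in this test and lower numbers for higher toxicity in this test. Compound 1 `C1CCCC2(CC1)OOC1(CCCCCC1)OO2` gives > 100 ug/mL, which is a limit of the assay. Compound 2 `CS(=O)(=O)N1CCC2(CC1)OOC1(CCCC1)OO2` gives > 100 ug/mL, again a limit. Compound 3 `CCS(=O)(=O)N1CCC2(CC1)OOC1(CCCCCC1)OO2` gives > 100 ug/mL, also a limit and not a number. For the measured compounds named here, the series so far stands as the limit of > 100 ug/mL in this assay, at which 3 of the 3 values shown sit, so compound 3 has no measured place of its own and no order can be read among the three.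

Compound 4 `O=S(=O)(CCCCl)N1CCC2(CC1)OOC1(CCCCCC1)OO2` differs from compound 3 by a single change, (chloromethyl in place of hydrogen on a saturated chain carbon, two bonds along the chain from a sulfonyl sulfur). This places chloromethyl in place of hydrogen on a saturated chain carbon, two bonds along the chain from a sulfonyl sulfur, turning ethylsulfonyl into (3-chloropropyl)sulfonyl. Going by the values given here, no measured pair gives a step in this assay, and no measured compound carries chlorine, so the size of this change has no direct precedent. The working expectation is no shift beyond the usual scatter, with no direction favoured, and a reading at the same limit is the likeliest outcome. The expected step is a number no higher from compound 3 to compound 4 (the limit leaves the size open). For compound 4 the estimated value is 100 ug/mL, with an expected range from 40 ug/mL to 200 ug/mL.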

Compound 4, half-maximal cytotoxic concentration: > 100 ug/mL
Compound 4: a limit, no number; the forecaster's own chance of this, stated with the estimate: 70%; the middle value sits exactly at the limit.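

In this assay compound 4 gives > 100 ug/mL and this is a limit, not a number. No step can be read between compound 3 and compound 4, as both stand at a limit: the limit of > 100 ug/mL in this assay, at which 4 of the 4 values shown sit. The compounds shown leave open at what concentration, if any, compound 1, compound 2, compound 3 or compound 4 would show toxicity in this test.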